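Amide substituent change at the lowest-clearance point

The source may report more compounds than this note shows. Statements on the series, on what has been measured and on what is new or still open speak of the compounds shown alone.

Compound 2 `CN1C[C@H](C(=O)Nc2ccc(Br)cc2)[C@@H](c2ccc(/C=C/C(=O)Nc3ccccc3N)cc2)C1` gives the lowest number of the three in an in vitro ADME assay on microsomes from liver (Homo sapiens) for pharmacokinetics, read by LC-MS, with a stated time of 10 min, tested at 1 uM (a lower number here means slower removal, a higher number faster removal of the compound), at 3 mL/min/kg. Compound 1 `COc1ccc(NC(=O)[C@H]2CN(C)C[C@@H]2c2ccc(/C=C/C(=O)Nc3ccccc3N)cc2)cc1` gives 14 mL/min/kg, and compound 3 `Cc1ccc(NC(=O)[C@H]2CN(C)C[C@@H]2c2ccc(/C=C/C(=O)Nc3ccccc3N)cc2)cn1` gives 8 mL/min/kg; the step of a 1.8-fold lower number from compound 1 to compound 3 (0.24 log units; within the scatter) separates these two only within the scatter. Both measured steps that touch compound 2 move the number upward when read away from it: a 2.7-fold higher number from compound 2 to compound 3 (0.43 log units; beyond the scatter), and a 4.7-fold lower number from compound 1 to compound 2 (0.67 log units; beyond the scatter) taken in reverse. Compound 4 `CN1C[C@H](C(=O)NC2CC2)[C@@H](c2ccc(/C=C/C(=O)Nc3ccccc3N)cc2)C1` carries the change (cyclopropyl in place of 4-bromophenyl on an amide-type nitrogen). Going by the values given here, no measured step exchanges the six-membered aromatic ring on the amide nitrogen for a three-membered non-aromatic ring, so the measured steps give direction and scale rather than a direct precedent. Since every departure from compound 2 so far has returned a modestly higher number, an upward step of similar size is expected, with a wide range. The expected step is a 2.7-fold higher number from compound 2 to compound 4 (0.43 log units; beyond the scatter). Compound 4 is estimated to give about 8 mL/min/kg, between 3 mL/min/kg and 20 mL/min/kg.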

Compound 4, clearance: 10 mL/min/kg
Estimate against measurement, compound 4: 1.3-fold (0.10 log units) below; the measured number falls inside the stated range.
By their numbers in this assay, from the lowest: compound 2; then compounds 3, 4 and 1 (each within the scatter of the next).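

Working notes, amide-type nitrogen: in this assay, the low number of compound 2 is not kept when cyclopropyl replaces 4-bromophenyl (a 3.3-fold higher number from compound 2 to compound 4 (0.52 log units; beyond the scatter)). Cyclopropyl stays within the scatter of both 6-methylpyridin-3-yl (a 1.3-fold higher number from compound 3 to compound 4 (0.10 log units; within the scatter)) and 4-methoxyphenyl (a 1.4-fold lower number from compound 1 to compound 4 (0.15 log units; within the scatter)), so among these compounds a six-membered aromatic ring on this nitrogen does not by itself give the low number, and only compound 2 stands apart. Nothing measured here explains why the 4-bromophenyl compound stands apart.

Still open, going by these compounds, is whether the separation depends on the bromine or on the whole 4-bromophenyl group, a question a 4-chlorophenyl group at this place would address. A longer chain ending in an amine would show how a group without a ring behaves on this nitrogen.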